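Replacing a furan amide by a methoxyphenoxy group on the chain

This account rests on a few compounds, and the source may have more. Where it says the series, first, only, none or still open, it means among the compounds named here.

For the measured compounds named here, the two compounds measured so far share one core and differ only in the group that hangs from the oxygen on the aromatic ring. Compound 1 `CC(C)=CCC/C(C)=C/CC1Cc2c(OCc3ccccc3)cc(=O)n(CCCO)c2CC1(C)C` gives 46.5% in a functional assay on PANC-1 cells (Homo sapiens) for inhibition, read by MTT assay, with a stated time of 24 h, tested at 10 uM; a lower number here means less inhibition, a higher number more inhibition at the concentration tested (going by the name of the read-out). Going by the values given here, compound 2 `CC(C)=CCC/C(C)=C/CC1Cc2c(OCCCNC(=O)c3ccco3)cc(=O)n(CCCO)c2CC1(C)C` gives 69.5% in this assay, the higher of the two numbers, and the only measured step, a number 23 percentage points higher from compound 1 to compound 2 (beyond the scatter), separates them. Compound 3 `COc1ccc(OCCCOc2cc(=O)n(CCCO)c3c2CC(C/C=C(\C)CCC=C(C)C)C(C)(C)C3)cc1` is not yet measured. It differs from compound 2 in one place: 4-methoxyphenoxy in place of ((furan-2-yl)carbonyl)amino on a saturated chain carbon, three bonds along the chain from an oxygen on an aromatic ring. Among the compounds with values here, no measured step covers this exchange, and the one known step concerns a different part of the chain, so it bears on compound 3 only loosely, showing only that a change in the outer group of this chain went with a higher number in this assay. Compound 3 is therefore expected to give 58% in this assay, within 40% to 76%, a step of a number 11.5 percentage points lower from compound 2 to compound 3 (beyond the scatter) that may not exceed the scatter.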

Compound 3, a percentage reported as inhibition, at one concentration (the size of the read-out at that concentration, not a potency): 20%
Compound 3: the middle estimate sits 38 percentage points above what was measured, and the stated range ends above it.
By their numbers in this assay, from the lowest: compound 3; then compound 1; then compound 2.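

The exchange of ((furan-2-yl)carbonyl)amino for 4-methoxyphenoxy on this chain gives a number 49.5 percentage points lower from compound 2 to compound 3 (beyond the scatter) in this assay, so the chain alone does not secure the higher number seen for compound 2, and the end group has a large bearing on the result. Set against the shorter phenyl-bearing group, 2-(4-methoxyphenoxy)ethyl gives a number 26.5 percentage points lower from compound 1 to compound 3 (beyond the scatter), whereas the furan amide chain had gone the other way, so among these three compounds the direction of the change depends on the group at the chain end. No evidence is at hand on what lies behind this fall.

The compounds shown leave open whether the furan ring or the amide carries the higher number, as the two leave together. From the compounds shown here alone, how a plain amine, a carboxylic acid or a longer chain at this position would read also remains open.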